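The source may hold more compounds than are shown below. What is called first, only, known or untested is meant among the compounds shown, and "the series" means these compounds.

Working notes on the series. Compound 3 `CC1CCN(c2c(S(=O)(=O)c3ccccc3)cnc3cc(Cl)ccc23)CC1` gives 93% in an assay on isolated protein for displacement of a labelled ligand from metabotropic glutamate receptor 5 (Homo sapiens), with a stated time of 60 min, tested at 1 uM (a lower number here means less inhibition, a higher number more inhibition at the concentration tested (going by the name of the read-out)), and carries the largest of the three numbers shown, though neither gap separates it from the others: compound 2 `Cc1ccc(S(=O)(=O)c2cnc3cc(F)ccc3c2N2CCC(C)CC2)cc1C` gives 90% and compound 1 `CC1CCN(c2c(S(=O)(=O)c3ccccc3)cnc3ccccc23)CC1` gives 89.2%, both within the scatter of compound 3. For the measured compounds named here, the one single-point step measured so far, a number 3.8 percentage points higher from compound 1 to compound 3 (within the scatter), puts chloro in place of hydrogen on the aromatic carbon and stays within the scatter.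

Compound 4 `CC1CCN(c2c(S(=O)(=O)c3ccccc3)cnc3cc(F)ccc23)CC1` is the next member, and it differs from compound 3 by fluoro in place of chloro on an aromatic carbon. Going by the values given here, no measured step exchanges chloro for fluoro directly. Two observations bear on it: the chloro for hydrogen step from compound 1 to compound 3 is within the scatter, and compound 2, which already carries fluoro on this ring with a different aryl on the sulfonyl, gives a value within the scatter of compound 3. Given that the halogen change from compound 1 to compound 3 moved this assay only a number 3.8 percentage points higher from compound 1 to compound 3 (within the scatter), no step beyond the scatter is expected here, and compound 4 is estimated at 90% with a range of 82% to 96%, a step of a number 3 percentage points lower from compound 3 to compound 4 (within the scatter).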

Compound 4, a percentage reported as inhibition, at one concentration (the size of the read-out at that concentration, not a potency): 87%
Compound 4: middle estimate off by 3 percentage points, on the high side; low and high end bracket the measured number.
By their numbers in this assay, from the lowest: compounds 4, 1, 2 and 3 (each within the scatter of the next).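

On this aromatic carbon, meta to a fused ring and para to a fused ring, the exchange of halogens now has a direct reading in this assay: fluoro in place of chloro gives a number 6 percentage points lower from compound 3 to compound 4 (within the scatter), and fluoro in place of hydrogen gives a number 2.2 percentage points lower from compound 1 to compound 4 (within the scatter), so that, together with the earlier chloro for hydrogen step, none of the three substituents at this place is separated from the others. The group on the sulfonyl sulfur also has its first single-place step, with phenyl in place of 3,4-dimethylphenyl giving a number 3 percentage points lower from compound 2 to compound 4 (within the scatter), so this change likewise goes unresolved at the one concentration tested. Nothing available explains why these numbers sit so close together.

With all four compounds reading so high at a single concentration, the compounds shown leave open whether their potencies differ at all, a question that a full concentration-response measurement could address. Also open, as far as these compounds go, is how this assay responds to a group of another kind, such as an amine or a nitrile on this aromatic carbon, or a carboxylic acid on the phenyl ring.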